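This account rests on a few compounds, and the source may have more. Where it says the series, first, only, none or still open, it means among the compounds named here.

Measured compounds:
- Compound 1, `CN1CCN(CC(=O)NC2(c3ccc(Cl)cc3)C(=O)Nc3cc(Cl)c(Cl)cc32)CC1`, in an in vitro functional assay on CHO-CREluc cells for antagonist activity at growth hormone secretagogue receptor type 1 (Homo sapiens), read by a luciferase reporter, with a stated time of 4 h (a lower number here means a stronger inhibitor, a higher number a weaker inhibitor), compound 1 gives > 10000 nM, a limit of the assay.
- Compound 2, `CN(C)CCN(C)CC(=O)NC1(c2ccc(Cl)cc2)C(=O)Nc2cc(Cl)c(Cl)cc21`, in this assay compound 2 gives > 10000 nM, again a limit.
- Compound 3, `CCN1CCN(CC(=O)NC2(c3ccc(Cl)cc3)C(=O)Nc3cc(Cl)c(C)cc32)CC1`, in this assay compound 3 gives 129 nM.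

Within the data shown here, compound 3 is the only compound with a number in this assay; the other two values sit at the limit of > 10000 nM in this assay, at which 2 of the 3 values shown sit. Among the measured compounds shown here, the one step among measured compounds, a step that the two limits leave unreadable from compound 1 to compound 2, is left unreadable by those two limits and concerns the amine end of the chain, not the aromatic ring.

Compound 4, `CCN1CCN(CC(=O)NC2(c3ccc(Cl)cc3)C(=O)Nc3cc(Cl)c(Cl)cc32)CC1`, differs from compound 3 by chloro in place of methyl on an aromatic carbon. No measured step touches this position, so nothing shown tells how large a step to expect in this assay or in which direction. The estimate for compound 4 therefore stays close to compound 3, with a wide range: a 2.3-fold higher number from compound 3 to compound 4 (0.37 log units; beyond the scatter) is expected, giving compound 4 an estimated 300 nM with a range from 80 nM to 3000 nM.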

Compound 4, half-maximal inhibitory concentration: 110 nM
Estimate against measurement, compound 4: 2.7-fold (0.44 log units) above; the range from low to high includes it.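

At this aromatic carbon, ortho to a chloro group, chloro in place of methyl leaves the read-out in this assay within the scatter, with a 1.2-fold lower number from compound 3 to compound 4 (0.07 log units; within the scatter). With chloro held there, the amine end decides the result: 4-ethylpiperazin-1-yl in place of (2-(dimethylamino)ethyl)(methyl)amino gives an at least 90-fold lower number from compound 2 to compound 4 (1.95 log units; beyond the scatter), and methyl in place of hydrogen on the saturated chain carbon bound to an amine nitrogen in a ring gives an at least 90-fold lower number from compound 1 to compound 4 (1.95 log units; beyond the scatter). Both of these large steps start from a limit of the assay, not from a number: the limit of > 10000 nM in this assay, at which 2 of the 4 values shown sit.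

On these data alone, whether hydrogen, fluoro or methoxy on this aromatic carbon would keep the read-out at the same level stays open. So does the read-out in this assay for a longer chain, such as propyl, in place of the ethyl of 4-ethylpiperazin-1-yl.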